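The compounds below may be only part of what the source reports. "The series", "measured", "known", "first", "only" and "open" are said of these compounds alone.

Measured so far in a functional assay on HCT-116 cells (Homo sapiens) for antiproliferative activity, read by MTT assay, with a stated time of 48 h; a lower number here means a stronger inhibitor, a higher number a weaker inhibitor
- Compound 1 `CCOc1cc(-c2ccc3[nH]ccc3c2)cn2c(-c3cc(OC)c(OC)c(OC)c3)nnc12` gives 374 nM
- Compound 2 `COc1cc(-c2nnc3c(OCC(F)(F)F)cc(-c4ccc5[nH]ccc5c4)cn23)cc(OC)c1OC` gives 900 nM

Compound 2 holds the higher of these two numbers, which makes it the weaker inhibitor of the pair in this assay. Compound 3 `COc1cc(-c2nnc3c(OC4CC4)cc(-c4ccc5[nH]ccc5c4)cn23)cc(OC)c1OC` has not yet been measured. It differs from compound 2 by one exchange, cyclopropyl in place of 2,2,2-trifluoroethyl on an oxygen on an aromatic ring.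

Among the measured compounds shown here, only one measured step bears on this exchange. It is a 2.4-fold higher number from compound 1 to compound 2 (0.38 log units; beyond the scatter), a modest step that came with trifluoromethyl in place of methyl. For the measured compounds named here, compound 3 also gives up the 2,2,2-trifluoroethyl, but no compound measured so far carries cyclopropyl, so that step guides the size of the expectation and does not fix it. A modest move towards a lower number is therefore expected, near the level of compound 1 (374 nM). The expected step is a 2.1-fold lower number from compound 2 to compound 3 (0.33 log units; beyond the scatter). For compound 3 the estimated value is 420 nM, with an expected range from 150 nM to 1200 nM.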

Compound 3, half-maximal inhibitory concentration: 275 nM
Compound 3: middle estimate off by 1.5-fold (0.18 log units), on the high side; measured number inside the range.
By their numbers in this assay, from the lowest: compounds 3 and 1 (each within the scatter of the next); then compound 2.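

Compound 3 shows that, in this assay, the oxygen on the aromatic ring can carry a three-membered non-aromatic ring of carbon only, whereas the earlier compounds had shown only the open chains ethyl and 2,2,2-trifluoroethyl at this place. The exchange of 2,2,2-trifluoroethyl for cyclopropyl gives a 3.3-fold lower number from compound 2 to compound 3 (0.51 log units; beyond the scatter), and the exchange of ethyl for cyclopropyl gives a 1.4-fold lower number from compound 1 to compound 3 (0.13 log units; within the scatter), so this assay does not separate cyclopropyl from ethyl, and among these three groups only 2,2,2-trifluoroethyl stands apart. Nothing available explains why the 2,2,2-trifluoroethyl compound differs from the other two.

From the compounds shown here alone, it remains open whether a longer chain such as butyl, a larger ring such as cyclohexyl, or a chain ending in an amine on the same oxygen would stay level with compound 1 and compound 3 or move away from them. The three compounds also share one core, so they leave open whether the same exchanges would give steps of this size on a different core.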